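Fluoro, methoxy, trifluoromethyl: one aryl substituent, three variants

A few compounds are considered here, and "the series" means these few. Any claim that something is new, unique, unknown or untested is made for them only; others in the source may bear on it.

Compound 1 `Cc1nc(-c2ccc(F)cc2)sc1COc1ccc2c(c1)OCC2CC(=O)O`: 79 nM
Compound 2 `COc1ccc(-c2nc(C)c(COc3ccc4c(c3)OCC4CC(=O)O)s2)cc1`: 156 nM

In an assay on CHO cells for agonist activity at Free fatty acid receptor 1 (Homo sapiens), read by FLIPR (a higher number here means that more compound is needed for the effect, a lower number that less compound is needed), compound 2 gives the higher of the two numbers seen so far, but the step of a 2.0-fold higher number from compound 1 to compound 2 (0.30 log units; within the scatter) is within the scatter, so the two compounds cannot be ranked. Compound 3 `Cc1nc(-c2ccc(C(F)(F)F)cc2)sc1COc1ccc2c(c1)OCC2CC(=O)O` carries the change (trifluoromethyl in place of methoxy on an aromatic carbon). Among the compounds with values here, the only step that bears on this place is a 2.0-fold higher number from compound 1 to compound 2 (0.30 log units; within the scatter), and it was small. For compound 3, with a trifluoromethyl on an aromatic carbon of a six-membered aromatic ring of carbon only, the expected step is therefore a 1.4-fold lower number from compound 2 to compound 3 (0.15 log units; within the scatter). The estimate for compound 3 is 110 nM, in the range 40 nM to 300 nM.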

Compound 3, half-maximal effective concentration: 113 nM
Compound 3: middle estimate off by 1.0-fold (0.01 log units), on the low side; low and high end bracket the measured number.
By their numbers in this assay, from the lowest: compounds 1, 3 and 2 (each within the scatter of the next).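

In this assay, the step is a 1.4-fold lower number from compound 2 to compound 3 (0.14 log units; within the scatter) for trifluoromethyl in place of methoxy, and a 1.4-fold higher number from compound 1 to compound 3 (0.16 log units; within the scatter) for trifluoromethyl in place of fluoro, so neither step can be ranked. With a third group on this aromatic carbon, para to a large group, all three compounds now sit within the scatter of the next, and this position has not yet given a clear difference. Nothing measured here offers an explanation.

Still open, on these data alone, is whether a different kind of group here, such as an amine, a carboxylic acid or a longer chain, would shift the number beyond the scatter.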